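The compounds below may be only part of what the source reports. "The series", "measured", "known", "first", "only" and "open" are said of these compounds alone.

Compound 3 `COc1ccccc1-c1sc(N)c(C(=O)c2ccc(Cl)cc2)c1CC(C)(C)C` stands level with the rest of the set in an assay on CHO cells for displacement of a labelled ligand from adenosine receptor A1 (Homo sapiens), read by scintillation counting, tested at 10 uM; a higher number here means more inhibition at the concentration tested (going by the name of the read-out), a lower number less inhibition: compound 3 gives 1%. Compound 1 `COc1ccc(-c2sc(N)c(C(=O)c3ccc(Cl)cc3)c2C)cc1` gives 1% in this assay, and compound 2 `CC(C)(C)Cc1c(-c2ccncc2)sc(N)c1C(=O)c1ccc(Cl)cc1` gives 1%. Among the measured compounds shown here, the single measured step, no change at the digits printed from compound 2 to compound 3 (within the scatter), stayed within the scatter. Compound 4 `COc1ccc(-c2sc(N)c(C(=O)c3ccc(Cl)cc3)c2CC(C)(C)C)cc1` is the next member; the change from compound 3 is 4-methoxyphenyl in place of 2-methoxyphenyl on an aromatic carbon. The step from compound 2 to compound 3 concerns the same aromatic carbon and is the only one that bears here; it showed nothing beyond the scatter, and compound 1, which already carries the entering group, also sits at 1%. For compound 4 the expected step is no change at the digits printed from compound 3 to compound 4 (within the scatter), none beyond the scatter. Compound 4 is therefore estimated at 1%, with a range from -9% to 11%.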

Compound 4, a percentage reported as inhibition, at one concentration (the size of the read-out at that concentration, not a potency): 1%
Estimate against measurement, compound 4: no gap at the digits printed; low and high end bracket the measured number.
By their numbers in this assay, from the lowest: compounds 1, 2, 3 and 4 (each within the scatter of the next).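

At the aromatic carbon next to the ring sulfur, 4-methoxyphenyl in place of 2-methoxyphenyl gives no change at the digits printed from compound 3 to compound 4 (within the scatter) in this assay, so the methoxy placement tested here does not separate the pair. 4-Methoxyphenyl in place of pyridin-4-yl gives no change at the digits printed from compound 2 to compound 4 (within the scatter), while tert-butyl in place of hydrogen on the saturated chain carbon gives no change at the digits printed from compound 1 to compound 4 (within the scatter), extending the flat reading to the neighbouring chain. No supporting data bear on this outcome.

Open, on these data alone, is whether an amine or carboxylic acid on the phenyl ring at this carbon, or a longer chain in place of neopentyl, would depart from this level.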